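The source may hold more compounds than are shown below. What is called first, only, known or untested is meant among the compounds shown, and "the series" means these compounds.

Measured in a functional assay on HeLa cells (Homo sapiens) for inhibition, read by MTT assay, with a stated time of 72 h; on this read-out lower numbers stand for stronger inhibition and higher numbers for weaker inhibition:
Compound 1 `Clc1cccc(Nc2nnc(-c3c[nH]c4ccccc34)o2)c1`: 5600 nM
Compound 2 `Cc1ccc(Nc2nnc(-c3c[nH]c4ccccc34)o2)cc1`: 15800 nM

Of these two, compound 2 holds the higher number, 15800 nM, and so the weaker inhibition. Compound 3 `c1ccc(CNc2nnc(-c3c[nH]c4ccccc34)o2)cc1` carries benzyl in place of 4-methylphenyl on a nitrogen on an aromatic ring. Among the measured compounds shown here, one measured step bears on this change, a modest one at the same place: a 2.8-fold higher number from compound 1 to compound 2 (0.45 log units; beyond the scatter). It exchanges different groups, so it suggests a size but no firm direction. In this assay, a change no larger than that is expected, leaning slightly towards a lower number. The estimated step is a 1.4-fold lower number from compound 2 to compound 3 (0.16 log units; within the scatter). For compound 3 the estimated value is 11000 nM, with an expected range of 4000 nM to 30000 nM.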

Compound 3, half-maximal inhibitory concentration: 7810 nM
For compound 3 the middle estimate is 1.4-fold (0.15 log units) above the measured one, and the stated range covers the measured number.
By their numbers in this assay, from the lowest: compounds 1 and 3 (each within the scatter of the next); then compound 2.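

Benzyl and 4-methylphenyl hold the same atoms, joined differently, and in this assay that exchange gives a 2.0-fold lower number from compound 2 to compound 3 (0.31 log units; beyond the scatter) and so shows that this place on the nitrogen responds to how the atoms are joined, not only to which atoms are present. Benzyl in place of 3-chlorophenyl gives a 1.4-fold higher number from compound 1 to compound 3 (0.14 log units; within the scatter) and so sets no order between these two groups. No available evidence accounts for either step.

Still open, from the compounds shown here alone, is how a longer chain ending in the same phenyl ring would read at this nitrogen. Going by these compounds, the effect of an amine or a carboxylic acid on that ring also remains open.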